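Swapping the Amide Aryl Ring for a Trifluoromethylpyridine

The source may hold more compounds than are shown below. What is called first, only, known or untested is meant among the compounds shown, and "the series" means these compounds.

Compound 2 `CN1CCN(c2ccc(Nc3nc(-c4cccc(NC(=O)c5ccccc5F)c4)sc3C(N)=O)cc2)CC1` holds the highest of the two numbers recorded so far in a functional assay on Raji cells (Homo sapiens) for antiproliferative activity, read by CCK-8 assay, with a stated time of 72 h (on this read-out higher numbers stand for weaker inhibition and lower numbers for stronger inhibition), where compound 2 gives 3270 nM. Its nearest neighbour, compound 1 `CN1CCN(c2ccc(Nc3nc(-c4cccc(NC(=O)c5ccc(C(F)(F)F)cc5)c4)sc3C(N)=O)cc2)CC1`, gives 3210 nM in this assay, and the two values lie within the scatter of each other. Within the data shown here, the single measured step, a 1.0-fold higher number from compound 1 to compound 2 (0.01 log units; within the scatter), therefore shows no movement that can be distinguished from repeat measurement noise.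

Compound 3 `CN1CCN(c2ccc(Nc3nc(-c4cccc(NC(=O)c5ccc(C(F)(F)F)cn5)c4)sc3C(N)=O)cc2)CC1` differs from compound 2 at the same position: 5-(trifluoromethyl)pyridin-2-yl in place of 2-fluorophenyl on a carbonyl carbon. Among the measured compounds shown here, the only measured step that bears on this change is a 1.0-fold higher number from compound 1 to compound 2 (0.01 log units; within the scatter), which exchanged one trifluoromethyl-bearing ring for the 2-fluorophenyl and stayed within the scatter; the entering group of compound 3 again carries a trifluoromethyl, now on a pyridine. For the measured compounds named here, no measured step separates a phenyl from a pyridine at this place, so nothing in the data points to a shift in either direction.

The step from compound 2 is expected to stay within the scatter, and compound 3 is estimated to show a 1.0-fold lower number from compound 2 to compound 3 (0.01 log units; within the scatter) in this assay. Compound 3 is accordingly estimated at 3200 nM in this assay, with an expected range from 1400 nM to 7500 nM.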

Compound 3, half-maximal inhibitory concentration: 24500 nM
The estimate for compound 3 lay 7.7-fold (0.88 log units) below the measured number, and the stated range ends below it.
By their numbers in this assay, from the lowest: compounds 1 and 2 (each within the scatter of the next); then compound 3.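

In this assay, the carbonyl-bound ring is not indifferent to change: compounds 1 and 2 could not be told apart, but 5-(trifluoromethyl)pyridin-2-yl in place of 2-fluorophenyl gives a 7.5-fold higher number from compound 2 to compound 3 (0.87 log units; beyond the scatter). The comparison with the other trifluoromethyl-bearing ring gives a 7.6-fold higher number from compound 1 to compound 3 (0.88 log units; beyond the scatter), so carrying a trifluoromethyl does not by itself set the number at this place, and among these three compounds, the one with a pyridine in place of a phenyl ring stands apart. No measurement on hand explains why this ring change weakens inhibition in these cells.

Compound 3 is the only pyridine among the compounds shown, so they leave open whether the ring nitrogen alone goes with the weaker inhibition or whether it does so only in combination with the trifluoromethyl. An unsubstituted pyridin-2-yl, a pyridin-2-yl carrying a fluorine in place of the trifluoromethyl, or a pyridin-3-yl with the same trifluoromethyl would each address a different part of that question.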